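Tetrazole replaces the hydroxy-isopropyl group on the shared core

The source may hold more compounds than are shown below. What is called first, only, known or untested is meant among the compounds shown, and "the series" means these compounds.

Measured compounds:
- compound 1, `CC(C)(O)c1cc(-c2ccccc2)c2ccc(OCc3cccc(C4(O)CCOCC4)c3)cc2c1`: 1500 nM
- compound 2, `N#Cc1cc(-c2ccccc2)c2ccc(OCc3cccc(C4(O)CCOCC4)c3)cc2c1`: 120 nM

In an assay on isolated protein with Polyunsaturated fatty acid 5-lipoxygenase (Homo sapiens) as the target (a lower number here means a stronger inhibitor, a higher number a weaker inhibitor), compound 1 gives 1500 nM, the highest of the two numbers measured; its nearest neighbour is compound 2, which in this assay gives 120 nM.

Going by the values given here, the one measured step bearing on the new compound is a 13-fold lower number from compound 1 to compound 2 (1.10 log units; beyond the scatter), in which the 1-hydroxy-1-methylethyl group of compound 1 is exchanged for a nitrile at the same aromatic carbon. That exchange brought a large change, well beyond the scatter.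

Compound 3, `Cn1nnc(-c2cc(-c3ccccc3)c3ccc(OCc4cccc(C5(O)CCOCC5)c4)cc3c2)n1`, is not yet measured. It differs from compound 1 by 2-methyl-2H-tetrazol-5-yl in place of 1-hydroxy-1-methylethyl on an aromatic carbon. As in compound 2, the group that leaves is the 1-hydroxy-1-methylethyl group with its one hydrogen-bond donor; what enters, like the nitrile, carries no hydrogen-bond donor, but here it is a five-membered aromatic ring rather than a small linear group. Among the compounds with values here, the only precedent therefore points to a lower number, while the size of the nitrile step need not carry over to a ring of this kind.

Taking the direction from compound 2 and allowing for the different shape of the entering group, a step of a 5.0-fold lower number from compound 1 to compound 3 (0.70 log units; beyond the scatter) is expected. Compound 3 is thus estimated at 300 nM in this assay, within a range of 80 nM to 1200 nM.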

Compound 3, half-maximal inhibitory concentration: 120 nM
Compound 3: middle estimate off by 2.5-fold (0.40 log units), on the high side, and the stated range covers the measured number.
By their numbers in this assay, from the lowest: compounds 2 and 3 (each within the scatter of the next); then compound 1.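

In this assay the large step first seen with the nitrile, a 13-fold lower number from compound 1 to compound 2 (1.10 log units; beyond the scatter), is not unique to that group: the 2-methyl-2H-tetrazol-5-yl group at the same aromatic carbon gives a 13-fold lower number from compound 1 to compound 3 (1.10 log units; beyond the scatter) as well. Between the two entering groups there is no change at the digits printed from compound 2 to compound 3 (within the scatter), so at this position the numbers do not separate a small linear group from a five-membered aromatic ring with 4 hetero atoms and 6 heavy atoms. No measurement at hand accounts for why these two groups read alike or why both stand apart from the 1-hydroxy-1-methylethyl group.

Still open, going by these compounds, is whether the lower number comes with the departure of the 1-hydroxy-1-methylethyl group or with what enters in its place, which a plain methyl group or a bare hydrogen on this aromatic carbon would help to separate. Also open, on these data alone, is whether an amine or a carboxylic acid here would stay with compounds 2 and 3 or move towards the number of compound 1.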